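The compounds below may be only part of what the source reports. "The series", "measured", "known", "first", "only" and "open" are said of these compounds alone.

Among the two compounds measured so far in an ADME assay on RAW264.7 cells (Mus musculus) for cytotoxicity, read by MTT assay, with a stated time of 24 h (a higher number here means that more compound is tolerated, a lower number that less compound is tolerated), compound 2 `CC/C=C\C[C@H]1C(=O)C=C[C@H]1CC(=O)Oc1ccccc1` stands highest, giving 158 uM, while compound 1 `CC/C=C\C[C@H]1C(=O)C=C[C@H]1CC(=O)OCCC` gives 35 uM. Within the data shown here, the only measured step, a 4.5-fold higher number from compound 1 to compound 2 (0.65 log units; beyond the scatter), went from a propyl chain to a phenyl. Compound 3 `CC/C=C\C[C@H]1C(=O)C=C[C@H]1CC(=O)OCCO` now differs from compound 2 by 2-hydroxyethyl in place of phenyl on an oxygen next to a carbonyl group. Since this change again trades the phenyl for a short chain, a drop of roughly the size seen between compound 1 and compound 2 seems plausible, though the hydroxyl is new and untested here. The expected step is a 3.2-fold lower number from compound 2 to compound 3 (0.50 log units; beyond the scatter). Compound 3 is therefore estimated at 50 uM, within 20 uM to 160 uM.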

Compound 3, half-maximal toxic concentration: 161 uM
Compound 3: middle estimate off by 3.2-fold (0.51 log units), on the low side; the whole stated range lies below it.
By their numbers in this assay, from the lowest: compound 1; then compounds 2 and 3 (each within the scatter of the next).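

In this assay, a ring is not required at this position on the oxygen next to a carbonyl group: 2-hydroxyethyl matches phenyl (a 1.0-fold higher number from compound 2 to compound 3 (0.01 log units; within the scatter)). What separates the short chains is their end, with hydroxy in place of methyl (a 4.6-fold higher number from compound 1 to compound 3 (0.66 log units; beyond the scatter)), so the earlier drop-off does not apply to every chain. Nothing at hand explains this result. From the compounds shown here alone, whether the hydroxy itself is needed remains open, as an amine or a carboxylic acid at the chain end could show. A longer chain ending in hydroxy is equally untested here.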